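The source may report more compounds than this note shows. Statements on the series, on what has been measured and on what is new or still open speak of the compounds shown alone.

In a functional assay on MOLT-4 cells (Homo sapiens) for cytotoxicity, read by CCK-8 assay, with a stated time of 72 h (on this read-out lower numbers stand for stronger inhibition and higher numbers for weaker inhibition), compound 2 `C=CCn1c(=O)/c(=C\c2ccccc2OC)[nH]c(=O)/c1=C\c1ccccc1OC` gives 13100 nM, the higher of the two numbers recorded so far. Compound 1 `C=CCn1c(=O)/c(=C\c2cccc(Cl)c2)[nH]c(=O)/c1=C\c1ccccc1OC` gives 4900 nM in this assay. Compound 3 `C=CCn1c(=O)/c(=C\c2cccc(Br)c2)[nH]c(=O)/c1=C\c1ccccc1OC` differs from compound 2 by 3-bromophenyl in place of 2-methoxyphenyl on a double-bonded chain carbon bound to an aromatic carbon. Within the data shown here, the single measured step that bears on this exchange is a 2.7-fold higher number from compound 1 to compound 2 (0.43 log units; beyond the scatter), which is essentially the same swap run in reverse, with 3-chlorophenyl rather than 3-bromophenyl. A lower number of roughly that size is therefore expected for compound 3, estimated at 4500 nM in this assay, with a range from 2000 nM to 10000 nM. From compound 2 the expected step is a 2.9-fold lower number from compound 2 to compound 3 (0.46 log units; beyond the scatter).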

Compound 3, half-maximal inhibitory concentration: 5000 nM
Estimate against measurement, compound 3: 1.1-fold (0.05 log units) below; measured number inside the range.
By their numbers in this assay, from the lowest: compounds 1 and 3 (each within the scatter of the next); then compound 2.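

In this assay, the step of a 2.6-fold lower number from compound 2 to compound 3 (0.42 log units; beyond the scatter) shows that the lower number seen with 3-chlorophenyl on this double-bonded chain carbon also appears with 3-bromophenyl. Bromo in place of chloro on an aromatic carbon gives a 1.0-fold higher number from compound 1 to compound 3 (0.01 log units; within the scatter), so the two cannot be told apart here. Nothing available explains why either group differs from 2-methoxyphenyl. The compounds shown leave open how a fluoro, a nitrile or an amine in place of the chloro or bromo would read. They also leave open whether the methoxy group itself or its place accounts for the higher number of compound 2.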